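Swapping the amide aryl group: from halogens to methoxy groups

A few compounds are considered here, and "the series" means these few. Any claim that something is new, unique, unknown or untested is made for them only; others in the source may bear on it.

Among the measured compounds shown here, compound 1 `O=C(CN1CCN(c2nnc(Cc3ccncc3)c3ccccc23)CC1)Nc1ccc(F)c(Cl)c1` gives 880 nM in a functional assay on HT-29 cells (Homo sapiens) for cytotoxicity, read by MTT assay, with a stated time of 72 h (on this read-out lower numbers stand for stronger inhibition and higher numbers for weaker inhibition), the lowest of the three numbers measured so far. For the measured compounds named here, compound 3 `O=C(CN1CCN(c2nnc(Cc3ccccc3)c3ccccc23)CC1)Nc1ccc(F)c(F)c1` is nearest to it with 9510 nM, and compound 2 `Cc1ccc(F)cc1NC(=O)CN1CCN(c2nnc(Cc3ccccc3)c3ccccc23)CC1` lies furthest away with 171000 nM; both differ from compound 1 in more than one place, so no single step connects them to it. Compound 4 `COc1ccc(NC(=O)CN2CCN(c3nnc(Cc4ccncc4)c4ccccc34)CC2)cc1OC` is compound 1 with 3,4-dimethoxyphenyl in place of 3-chloro-4-fluorophenyl on an amide-type nitrogen. Going by the values given here, the one measured step at the same place, an 18-fold lower number from compound 2 to compound 3 (1.25 log units; beyond the scatter), shows that changing the ring on the amide-type nitrogen can shift the number a great deal, but the groups involved there are not the ones exchanged here, and nothing measured tells in which direction two methoxy groups pull. Compound 4 is therefore expected to land somewhere above compound 1, with the step of a 5.7-fold higher number from compound 1 to compound 4 (0.75 log units; beyond the scatter) as the estimate. For compound 4 the expected value is 5000 nM, in a range from 1000 nM to 30000 nM.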

Compound 4, half-maximal inhibitory concentration: 40100 nM
Compound 4: the middle estimate sits 8.0-fold (0.90 log units) below what was measured, outside the stated range (above it).
By their numbers in this assay, from the lowest: compound 1; then compound 3; then compound 4; then compound 2.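

In this assay, the ring on the amide-type nitrogen now has a step read directly on the core of compound 1: 3,4-dimethoxyphenyl in place of 3-chloro-4-fluorophenyl gives a 46-fold higher number from compound 1 to compound 4 (1.66 log units; beyond the scatter). This settles the direction for this exchange, which is towards weaker inhibition, and it shows that a large shift from this position is not confined to the other core, where the step was an 18-fold lower number from compound 2 to compound 3 (1.25 log units; beyond the scatter). No measurement available here explains the rise, so it stands as an observation only.

As far as these compounds go, the exchange replaces both ring substituents at once, so the share of each one remains unknown. From the compounds shown here alone, it also remains open whether a phenyl ring carrying a single methoxy group, a hydroxy group or a nitrile would give a number closer to that of compound 1 or compound 4.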